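The source may report more compounds than this note shows. Statements on the series, on what has been measured and on what is new or still open speak of the compounds shown alone.

Measured so far in a functional assay on MCF7 cells (Homo sapiens) for cytotoxicity, read by sulforhodamine B assay, with a stated time of 24 h; on this read-out higher numbers stand for weaker inhibition and lower numbers for stronger inhibition:
- compound 1 `N/N=C1\C(=O)Nc2ccc(S(=O)(=O)N3CCOCC3)cc21`: 46800 nM
- compound 2 `O=C1Nc2ccc(S(=O)(=O)N3CCOCC3)cc2/C1=N/c1ccc(O)cc1`: 52700 nM

Within the data shown here, compound 1 holds the lowest of the two numbers so far in this assay. Its nearest neighbour is compound 2, and the step of a 1.1-fold higher number from compound 1 to compound 2 (0.05 log units; within the scatter) is given as within the scatter, so the two values cannot be ranked against each other on these data.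

Compound 3 `O=C1Nc2ccc(S(=O)(=O)N3CCOCC3)cc2/C1=N/c1ccc(C(=O)O)cc1` is not yet measured. It differs from compound 1 in one place: 4-carboxyphenyl in place of amino on a double-bonded nitrogen

Among the measured compounds shown here, the only step that bears on this change is the one from compound 1 to compound 2, where 4-hydroxyphenyl replaced amino on the same double-bonded nitrogen, and that step, a 1.1-fold higher number from compound 1 to compound 2 (0.05 log units; within the scatter), stayed within the scatter. A second aryl group entering at the same position, now 4-carboxyphenyl, is therefore expected to move the number by no more than the scatter as well, which is what a 1.1-fold higher number from compound 1 to compound 3 (0.05 log units; within the scatter) means. Compound 3 is accordingly estimated at 52000 nM in this assay, with a range from 22000 nM to 125000 nM. The estimate rests on a single comparison, compound 1 against compound 2, and is held loosely.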

Compound 3, half-maximal inhibitory concentration: 26700 nM
Compound 3: middle estimate off by 1.9-fold (0.29 log units), on the high side; the measured number falls inside the stated range.
By their numbers in this assay, from the lowest: compounds 3, 1 and 2 (each within the scatter of the next).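

In this assay, the double-bonded nitrogen now carries a second aryl group, and the change from amino to 4-carboxyphenyl reads a 1.8-fold lower number from compound 1 to compound 3 (0.24 log units; within the scatter), so amino, 4-hydroxyphenyl and 4-carboxyphenyl at this position all remain within the scatter of one another. The new comparison is the exchange on the aromatic carbon itself, which reads a 2.0-fold lower number from compound 2 to compound 3 (0.30 log units; within the scatter), so carboxy and hydroxy cannot be ranked on these data, and neither aryl group can be ranked against amino. No measurement is available that bears on why these three numbers stay together.

The compounds shown do not tell whether any group on the double-bonded nitrogen can move the number in this assay beyond the scatter, since all their steps lie within it and no simple alkyl chain or unsubstituted phenyl stands at this position. On these data alone, it also remains open whether an amine or a methoxy group in place of carboxy on the aromatic carbon would separate from compound 3 in this read-out.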